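Exchanging a Carboxy Group for a Methyl Group

The compounds below may be only part of what the source reports. "The series", "measured", "known", "first", "only" and "open" are said of these compounds alone.

Compound 1, with the structure `Cc1cc(C(=O)O)nn1-c1ccc(S(=O)(=O)N2CCC(=O)N(C3CCCCC3)C2=S)cc1`, was tested in a functional assay on the whole organism (blood, strain albino) with Mus musculus as the target, with stated times of 6 days and 3 h, at a dose of 1 mmol/kg by the oral route (on this read-out higher numbers stand for more inhibition at the one dose given (going by the name of the read-out) and lower numbers for less inhibition), where compound 1 gives 2%. Among the compounds with values here, the only other measured compound is compound 2, with the structure `CCN1C(=O)CCN(S(=O)(=O)c2ccc(-n3nc(C)cc3C)cc2)C1=S`, and in this assay compound 2 gives 4%. The two numbers sit within the usual scatter of each other, so neither result can be told apart from the other; both amount to almost no effect at the dose given. Within the data shown here, compound 1 and compound 2 differ in more than one place, so no clean step between two measured compounds is available here.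

Compound 3, with the structure `Cc1cc(C)n(-c2ccc(S(=O)(=O)N3CCC(=O)N(C4CCCCC4)C3=S)cc2)n1`, differs from compound 1 by the change (methyl in place of carboxy on an aromatic carbon). With compound 1 sitting near zero at 2%, and compound 2 also near zero at 4%, there is no basis for expecting a change larger than the scatter. The step from compound 1 to compound 3 is therefore expected to be about a number 3 percentage points higher from compound 1 to compound 3 (within the scatter). Compound 3 is estimated to give roughly 5%, most likely between -5% and 15%.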

Compound 3, a percentage reported as inhibition, in the whole organism at one dose (the size of the read-out at that dose, not a potency): 4%
For compound 3 the middle estimate is 1 percentage points above the measured one; measured number inside the range.
By their numbers in this assay, from the lowest: compounds 1, 2 and 3 (each within the scatter of the next).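

Within the data shown here, compound 3 gives the first comparison in which only this position differs: with methyl in place of carboxy on an aromatic carbon of the five-membered ring, this assay shows a number 2 percentage points higher from compound 1 to compound 3 (within the scatter) at the single oral dose, so the two groups cannot be told apart here. It also gives a one-place comparison elsewhere in the molecule, since cyclohexyl in place of ethyl on an amide-type nitrogen in a ring gives no change at the digits printed from compound 2 to compound 3 (within the scatter) and leaves those two groups equally hard to tell apart in this assay on this evidence. No measurement shown accounts for either result.

As far as these compounds go, all three numbers lie within the scatter of one another, so it remains open whether any group at this position can produce a clear reading in this test. An amine or a longer chain such as propyl on the same aromatic carbon could show whether this position matters at all, and the same question stands for a longer chain on the ring nitrogen that carries ethyl or cyclohexyl.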